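The compounds below may be only part of what the source reports. "The series", "measured", "known", "first", "only" and "open" are said of these compounds alone.

Of the compounds shown here, two from this series have been tested in a functional assay on MCF7 cells (Homo sapiens) for antiproliferative activity, read by MTT assay, with a stated time of 48 h; a lower number here means a stronger inhibitor, a higher number a weaker inhibitor. Among the measured compounds shown here, compound 1, with the structure `CCOc1ccc(-n2nncc2CN2C(=O)C3(C(C#N)=C(N)Oc4c3c3nc5ccccc5nc3c3ccccc43)c3ccccc32)cc1`, is the first. In this assay compound 1 gives only a limit of the assay, > 50000 nM, and not a number. Compound 2, with the structure `N#CC1=C(N)Oc2c(N)cc3nc4ccccc4nc3c2C12C(=O)N(Cc1cnnn1-c1ccccc1Br)c1ccccc12`, is the second. In this assay, for the measured compounds named here, compound 2 gives 30700 nM, which is the only number so far. The other result, that of compound 1, is the limit described by the limit of > 50000 nM in this assay, at which 1 of the 2 values shown sits. Going by the values given here, compound 2 therefore stands alone as the one measured value.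

Compound 3, with the structure `N#CC1=C(N)Oc2c(N)cc3nc4ccccc4nc3c2C12C(=O)N(Cc1cnnn1-c1c(F)cccc1F)c1ccccc12`, has not yet been measured. It differs from compound 2 in a single place: 2,6-difluorophenyl in place of 2-bromophenyl on an aromatic nitrogen.

Among the compounds with values here, no measured pair in this set shows how such a change plays out, so there is no step to lean on. The expectation is therefore a modest one: from compound 2 to compound 3 the shift a 1.0-fold lower number from compound 2 to compound 3 (0.01 log units; within the scatter) is expected to stay within the usual scatter of repeated measurements, with no clear direction. Compound 3 is accordingly estimated to give 30000 nM, somewhere between 10000 nM and 90000 nM.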

Compound 3, half-maximal inhibitory concentration: > 50000 nM
Compound 3 gave a limit, no number; the forecaster's own chance of this, stated with the estimate: 30%; middle value at least 1.6-fold (0.22 log units) from the limit.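

Among the compounds shown here, this is the first step seen at this position, on an aromatic nitrogen of a five-membered aromatic ring with 3 nitrogen, and putting 2,6-difluorophenyl in place of 2-bromophenyl there gives an at least 1.6-fold higher number from compound 2 to compound 3 (0.21 log units; that floor lies within the scatter) in this assay. Compound 3 gives a limit and not a number, so the swap shows no sign of a stronger inhibitor, but the true size of the step cannot be read, and its floor does not establish a real loss. With this result, the limit, rather than measured numbers, describes most of the compounds shown: the limit of > 50000 nM in this assay, at which 2 of the 3 values shown sit.

The compounds shown leave open whether the bromine of compound 2 matters in itself, which a plain phenyl or a 2-chlorophenyl at the same position would help to test. For the compounds shown here, compound 2 gives 30700 nM, the only true number so far, so it also remains open whether an amine or a carboxylic acid on this phenyl ring would move the result clearly away from that value in either direction.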